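A few compounds are considered here, and "the series" means these few. Any claim that something is new, unique, unknown or untested is made for them only; others in the source may bear on it.

Compound 1 `NC(=O)c1c(NC(=O)Nc2ccc(Cl)cc2)sc2c1CCN(CC1CCCCC1)C2`: 1890 nM
Compound 2 `CC(C)(C)OC(=O)N1CCc2c(sc(NC(=O)Nc3ccc(Cl)cc3)c2C(N)=O)C1`: > 25000 nM, a limit
Compound 3 `CC(C)(C)OC(=O)CCN1CCc2c(sc(NC(=O)Nc3ccc(Cl)cc3)c2C(N)=O)C1`: 1100 nM

In a functional assay (strain AB) with Danio rerio as the target, read by microscopy, with a stated time of 1 h (on this read-out higher numbers stand for an effect only at larger amounts of compound and lower numbers for an effect already at smaller amounts), compound 3 gives 1100 nM, level with compound 1 within the scatter: a 1.7-fold lower number from compound 1 to compound 3 (0.24 log units; within the scatter). Compound 4 `NC(=O)c1c(NC(=O)Nc2ccc(Cl)cc2)sc2c1CCN(CCCNC(=O)CCc1cccnc1)C2` carries (((2-(pyridin-3-yl)ethyl)carbonyl)amino)methyl in place of the tert-butoxycarbonyl of compound 3, on a saturated chain carbon, two bonds along the chain from an amine nitrogen in a ring: (((2-(pyridin-3-yl)ethyl)carbonyl)amino)methyl in place of tert-butoxycarbonyl on a saturated chain carbon, two bonds along the chain from an amine nitrogen in a ring.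

For the measured compounds named here, the closest precedent is that exchange at the chain end, between compound 1 and compound 3, which stayed within the scatter. The large steps, an at least 13-fold higher number from compound 1 to compound 2 (1.12 log units; beyond the scatter) and an at least 22-fold lower number from compound 2 to compound 3 (1.35 log units; beyond the scatter), both involve compound 2, with tert-butoxycarbonyl on the amine nitrogen in a ring itself, and compound 4 lacks this feature. No step beyond the scatter is therefore expected in this assay. The expected step is a 1.4-fold higher number from compound 3 to compound 4 (0.13 log units; within the scatter). The estimate for compound 4 is 1500 nM, with an expected range of 400 nM to 6000 nM.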

Compound 4, half-maximal effective concentration: 470 nM
Compound 4: the middle estimate sits 3.2-fold (0.50 log units) above what was measured, within the range that was stated.
By their numbers in this assay, from the lowest: compound 4; then compounds 3 and 1 (each within the scatter of the next). At a limit, above all of these: compound 2.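

With (((2-(pyridin-3-yl)ethyl)carbonyl)amino)methyl in place of tert-butoxycarbonyl on a saturated chain carbon, this assay shows a 2.3-fold lower number from compound 3 to compound 4 (0.37 log units; beyond the scatter), so a change at the chain end can pass beyond the scatter, which the exchange between compound 1 and compound 3 did not do. The larger entering group, with its six-membered aromatic ring and hydrogen-bond donor, is thus compatible with a modestly lower number. Nothing shown here gives a cause for this step. As far as these compounds go, it remains open whether the step follows the pyridin-3-yl ring or the amide. A phenyl ring in place of the pyridin-3-yl ring, or a simple acetyl group on the chain amine, would separate the two.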